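The source may report more compounds than this note shows. Statements on the series, on what has been measured and on what is new or still open speak of the compounds shown alone.

Working notes on the series. The compounds share one core; compound 1 is `Cc1cc(NCc2nccn2C)n2nc(C)c(-c3ccccc3)c2n1` and compound 2 is `Cc1cc(NCc2ccccn2)n2ncc(-c3cccc(Cl)c3)c2n1`. Both have been run in an ADME assay on CHO cells (Cricetulus griseus) for cytotoxicity, read by MTT assay; on this read-out higher numbers stand for weaker inhibition and lower numbers for stronger inhibition. For compound 1 the assay returns only a limit, < 9000 nM. Among the measured compounds shown here, compound 2 gives 3780 nM in this assay, the only plain number in the set, so compound 2 stands as the single fixed point. The other entry, that of compound 1, is a limit (the limit of < 9000 nM in this assay, at which 1 of the 2 values shown sits). For the measured compounds named here, no step between two measured compounds is available, and the two values shown cannot be ordered against each other.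

Compound 3 is `Cc1cc(NCc2ccccn2)n2ncc(-c3ccccc3F)c2n1`, not yet measured. It differs from compound 2 in one place: 2-fluorophenyl in place of 3-chlorophenyl on an aromatic carbon. Nothing measured in the series bears on this kind of exchange, so the expectation rests on compound 2 alone. The step is expected to be small, a 1.3-fold higher number from compound 2 to compound 3 (0.12 log units; within the scatter), with no clear direction beyond the scatter. Compound 3 is therefore estimated at 5000 nM in this assay, within a range from 2000 nM to 12000 nM, and an outcome reported only as a limit remains possible.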

Compound 3, half-maximal inhibitory concentration: 5450 nM
Estimate against measurement, compound 3: 1.1-fold (0.04 log units) below; the measured number falls inside the stated range.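

In this assay, among the compounds shown here, the first step that can be read belongs to this aromatic carbon of the five-membered ring: 2-fluorophenyl in place of 3-chlorophenyl gives a 1.4-fold higher number from compound 2 to compound 3 (0.16 log units; within the scatter). The two compounds therefore stand within the scatter of each other, and this exchange, which moves the substituent on the phenyl ring and swaps chlorine for fluorine, gives no separation on this read-out, a finding limited to this one pair. Nothing shown gives a measured property that would bear on this step.

The entry for compound 1 is a limit, and steps involving it cannot be read: the limit of < 9000 nM in this assay, at which 1 of the 3 values shown sits.

Still open, going by these compounds, is whether a different kind of group on this aromatic carbon, such as an amine, a carboxylic acid or a saturated cyclohexyl ring in place of the substituted phenyl, would give a step beyond the scatter in this assay.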